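A few compounds are considered here, and "the series" means these few. Any claim that something is new, unique, unknown or untested is made for them only; others in the source may bear on it.

Measured compounds:

Compound 1 `CCCN(CCC(F)(F)F)Cc1c(C(F)(F)F)nc2n(-c3c(C)cc(C)cc3C)c(Cl)cn12` gives 12 nM in an assay on cells for displacement of a labelled ligand from corticotropin-releasing factor receptor 1 (Homo sapiens), with a stated time of 100 min; on this read-out higher numbers stand for weaker inhibition and lower numbers for stronger inhibition.
Compound 2 `C=C(C)CN(CC)Cc1c(C(F)(F)F)nc2n(-c3c(C)cc(C)cc3C)c(Cl)cn12` gives 67 nM in this assay.
Compound 3 `CCN(Cc1c(C(F)(F)F)nc2n(-c3c(C)cc(C)cc3C)c(Cl)cn12)CC1CCC1` gives 16 nM in this assay.

Among these three numbers compound 3 stands second highest. Its nearest neighbour is compound 1, with a 1.3-fold higher number from compound 1 to compound 3 (0.12 log units; within the scatter), so the two are not told apart. Its furthest neighbour is compound 2, with a 4.2-fold lower number from compound 2 to compound 3 (0.62 log units; beyond the scatter).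

The new compound, compound 4 `Cc1cc(C)c(-n2c(Cl)cn3c(CN4CCCCC4)c(C(F)(F)F)nc23)c(C)c1`, differs from compound 3 in one place: piperidin-1-yl in place of (cyclobutylmethyl)(ethyl)amino on a saturated chain carbon bound to an aromatic carbon. The measured steps that bear on this change all concern the amine attached at the same saturated chain carbon. Exchanging the two substituents on that nitrogen gave a 1.3-fold higher number from compound 1 to compound 3 (0.12 log units; within the scatter) in one case and a 5.6-fold higher number from compound 1 to compound 2 (0.75 log units; beyond the scatter) in another, while a 4.2-fold lower number from compound 2 to compound 3 (0.62 log units; beyond the scatter) shows that the cyclobutyl group recovered most of that loss. The amine of compound 4 is smaller than that of compound 3, so a modest weakening is expected, a 2.2-fold higher number from compound 3 to compound 4 (0.34 log units; beyond the scatter). Compound 4 is therefore estimated at 35 nM, within a range from 12 nM to 100 nM in this assay.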

Compound 4, inhibition constant: 1200 nM
For compound 4 the middle estimate is 34-fold (1.54 log units) below the measured one; the whole stated range lies below it.
By their numbers in this assay, from the lowest: compounds 1 and 3 (each within the scatter of the next); then compound 2; then compound 4.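

In this assay, piperidin-1-yl on this saturated chain carbon gives a large loss from every amine before it: a 75-fold higher number from compound 3 to compound 4 (1.88 log units; beyond the scatter), an 18-fold higher number from compound 2 to compound 4 (1.25 log units; beyond the scatter) and a 100-fold higher number from compound 1 to compound 4 (2.00 log units; beyond the scatter). The earlier compounds shown here all carried two separate substituents on the nitrogen, and their widest step was a 5.6-fold higher number from compound 1 to compound 2 (0.75 log units; beyond the scatter), so they showed how far such open amines can differ, but not that joining the two substituents into a ring could cost so much more. Nothing measured on these compounds accounts for the loss.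

The compounds shown do not separate the closing of the ring from the smaller size of the entering group. Diethylamino, which is open but small, and azepan-1-yl, a larger ring, at the same carbon would bear on that question.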